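This account rests on a few compounds, and the source may have more. Where it says the series, first, only, none or still open, it means among the compounds named here.

Of the compounds shown here, two built on one shared core have been tested in a functional assay on cells for agonist activity at Glucose-dependent insulinotropic receptor (Homo sapiens), read by a luciferase reporter, with a stated time of 4 h; on this read-out lower numbers stand for an effect already at smaller amounts and higher numbers for an effect only at larger amounts of compound. Compound 1 `CC(O)c1cnc(N2CCC(c3coc4c(N5CCc6cc(S(C)(=O)=O)ccc65)ncnc34)CC2)nc1` gives 586 nM. Among the compounds with values here, compound 2 `COc1cnc(N2CCC(c3coc4c(N5CCc6cc(S(C)(=O)=O)ccc65)ncnc34)CC2)nc1` gives 310 nM, the lowest of the two numbers, though its only neighbour sits close by: a 1.9-fold lower number from compound 1 to compound 2 (0.28 log units; within the scatter). Compound 3 `CS(=O)(=O)c1ccc2c(c1)CCN2c1ncnc2c(C3CCN(c4ncc(Cl)cn4)CC3)coc12` has not yet been measured. It differs from compound 2 in one place: chloro in place of methoxy on an aromatic carbon. Read one bond further out, the change runs from 5-methoxypyrimidin-2-yl to 5-chloropyrimidin-2-yl.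

Within the data shown here, only one measured step touches this part of the molecule, the one in which methoxy replaced 1-hydroxyethyl on an aromatic carbon, and that step stayed within the scatter. Among the measured compounds shown here, it is the sole guide available. Exchanging methoxy for chloro at that carbon is therefore expected to shift the number little, and the estimated step is a 1.0-fold lower number from compound 2 to compound 3 (0.01 log units; within the scatter). For compound 3 the estimate in this assay is 300 nM, with a range from 120 nM to 800 nM, the width reflecting that a single within-scatter step is a thin basis for expectation.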

Compound 3, half-maximal effective concentration: 42 nM
Compound 3: the middle estimate sits 7.1-fold (0.85 log units) above what was measured, and the stated range ends above it.
By their numbers in this assay, from the lowest: compound 3; then compounds 2 and 1 (each within the scatter of the next).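

In this assay, within the data shown here, the one earlier step at this aromatic carbon stayed within the scatter, which left open whether the group placed here mattered much; chloro in place of methoxy now gives a 7.4-fold lower number from compound 2 to compound 3 (0.87 log units; beyond the scatter), so the position clearly responds to what sits on it. Measured against the 1-hydroxyethyl group, the same chloro gives a 14-fold lower number from compound 1 to compound 3 (1.14 log units; beyond the scatter), which sets compound 3 apart from both other compounds, while those two stay within the scatter of each other and the 5-chloropyrimidin-2-yl group is the only one of the three to stand out. No measurement offered here explains why chloro does so much better at this carbon than either of the groups it replaced.

The three compounds cannot say whether this gain belongs to chlorine alone or would also appear with a fluoro, a bromo, a methyl or a nitrile on the same carbon. They also leave open whether chloro would bring a similar step if the methylsulfonyl group elsewhere on the shared core were exchanged for another group, such as an amide.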